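This account rests on a few compounds, and the source may have more. Where it says the series, first, only, none or still open, it means among the compounds named here.

Values in an ADME assay on Vero cells (Chlorocebus sabaeus) for cytotoxicity, read by neutral red uptake, with a stated time of 3 days; a higher number here means that more compound is tolerated, a lower number that less compound is tolerated:
compound 1 `CC(C)n1ncc2c(C(=O)NC3CCN(C)C3)cc(C3CC3)nc21`: 33800 nM
compound 2 `CC(C)n1ncc2c(C(=O)NCCN)cc(C(C)(C)C)nc21`: 23000 nM
compound 3 `Cc1cc(C(=O)NC2CCN(C)C2)c2cnn(C(C)C)c2n1`: > 300000 nM (a limit, not a number)

Compound 3 stands at the limit of > 300000 nM in this assay, at which 1 of the 3 values shown sits, and this is only a limit. Compound 4 `Cc1cc(C(=O)NC2CN(C)C2)c2cnn(C(C)C)c2n1` carries 1-methylazetidin-3-yl in place of 1-methylpyrrolidin-3-yl on an amide-type nitrogen. Among the compounds with values here, no measured step changes this group. Within the data shown here, the only single-place step measured, an at least 8.8-fold higher number from compound 1 to compound 3 (0.94 log units; beyond the scatter), is methyl in place of cyclopropyl on an aromatic carbon, and compound 4 keeps that methyl. On that basis, no change beyond the scatter is expected in this assay. The expected step is a number no higher from compound 3 to compound 4 (the limit leaves the size open). For compound 4 the estimated value is 300000 nM, with an expected range of 100000 nM to 600000 nM.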

Compound 4, half-maximal cytotoxic concentration: > 300000 nM
Compound 4 ended at the assay's limit (the forecaster's own chance of this, stated with the estimate: 55%); the middle value sits exactly at the limit.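

Compound 3 and compound 4 both stand at a limit, not a number, so no step can be read between them: the limit of > 300000 nM in this assay, at which 2 of the 4 values shown sit.

Open remains whether 1-methylazetidin-3-yl in place of 1-methylpyrrolidin-3-yl on an amide-type nitrogen changes the number in this assay at all.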